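A few compounds are considered here, and "the series" means these few. Any claim that something is new, unique, unknown or untested is made for them only; others in the source may bear on it.

Compounds measured in a functional assay on SW-620 cells (Homo sapiens) for antiproliferative activity, read by MTT assay, with a stated time of 72 h; on this read-out higher numbers stand for weaker inhibition and lower numbers for stronger inhibition:

- Compound 1 `O=C1O[C@H]([C@@H](O)Cn2cc(-c3cc(C(F)(F)F)cc(C(F)(F)F)c3)nn2)C(OCc2ccccc2)=C1OCc1ccccc1`: 49200 nM
- Compound 2 `O=C1O[C@H]([C@@H](O)Cn2cc(-c3cccc(O)c3)nn2)C(OCc2ccccc2)=C1OCc1ccccc1`: > 100000 nM (a limit of the assay, not a number)
- Compound 3 `CCCCc1cn(C[C@H](O)[C@H]2OC(=O)C(OCc3ccccc3)=C2OCc2ccccc2)nn1`: 47500 nM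

Within the data shown here, compound 3, at 47500 nM, lies within the usual scatter of compound 1, and these two are the only true numbers so far in this assay. Compound 2 gives only a limit, > 100000 nM.

The next compound to be tested is compound 4 `O=C1O[C@H]([C@@H](O)Cn2cc(CNS(=O)(=O)c3ccc(F)cc3)nn2)C(OCc2ccccc2)=C1OCc1ccccc1`, which differs from compound 3 by one change: ((4-fluorophenyl)sulfonyl)amino in place of propyl on a saturated chain carbon bound to an aromatic carbon. Cut one bond further out, this reads butyl to (((4-fluorophenyl)sulfonyl)amino)methyl. Among the measured compounds shown here, the one measured step at this substituent is an at least 2.1-fold lower number from compound 2 to compound 3 (0.32 log units; beyond the scatter), which hints that an aryl group there gives weaker inhibition than butyl. Compound 1 goes against that hint, since it carries an aryl group there and still gives 49200 nM. No step beyond the scatter is therefore expected, and any drift should be towards weaker inhibition. The expected change is a 1.4-fold higher number from compound 3 to compound 4 (0.14 log units; within the scatter). For compound 4 the estimated value is 65000 nM, with an expected range from 25000 nM to 100000 nM.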

Compound 4, half-maximal inhibitory concentration: 41100 nM
Estimate against measurement, compound 4: 1.6-fold (0.20 log units) above, within the range that was stated.
By their numbers in this assay, from the lowest: compounds 4, 3 and 1 (each within the scatter of the next). At a limit, above all of these: compound 2.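

In this assay, the far larger (((4-fluorophenyl)sulfonyl)amino)methyl group, which brings in an aromatic ring and a sulfonyl amino link, takes the place of butyl with no change beyond the scatter (a 1.2-fold lower number from compound 3 to compound 4 (0.06 log units; within the scatter)). Set against 3-hydroxyphenyl, the same group gives a step beyond the scatter (an at least 2.4-fold lower number from compound 2 to compound 4 (0.38 log units; beyond the scatter)), so an aryl ring held out on a saturated chain carbon does not go with the weaker inhibition of compound 2. That step has only one firm end, since compound 2 stays at a limit of the assay: the limit of > 100000 nM in this assay, at which 1 of the 4 values shown sits.

What the compounds shown leave open is whether any group at this position can give inhibition clearly stronger than that of compound 1, compound 3 and compound 4. On these data alone, a free amine, a carboxylic acid or a longer alkyl chain there remains untested among them, as does the sulfonyl amino link without its 4-fluorophenyl ring.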